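The source may report more compounds than this note shows. Statements on the series, on what has been measured and on what is new or still open speak of the compounds shown alone.

Measured in a functional assay on LOX IMVI cells (Homo sapiens) for cytotoxicity, read by MTT assay, with a stated time of 24 h; on this read-out lower numbers stand for stronger inhibition and higher numbers for weaker inhibition:
- compound 1 `O=S(=O)(NCCCNc1nccc(-c2[nH]c(-c3ccccc3)nc2-c2ccc(F)c(O)c2)n1)c1cccc2ccccc12` gives 3710 nM
- compound 2 `O=S(=O)(NCCCNc1nccc(-c2[nH]c(-c3ccccc3)nc2-c2ccc(Cl)c(O)c2)n1)c1ccc(Br)cc1` gives 15500 nM
- compound 3 `O=S(=O)(NCCCNc1nccc(-c2[nH]c(-c3ccccc3)nc2-c2ccc(Cl)c(O)c2)n1)c1ccc(C(F)(F)F)cc1` gives 10100 nM

Compound 3 sits level with compound 2, within the scatter of it, and both numbers lie above that of compound 1. The next compound to consider is compound 4 `O=S(=O)(NCCCNc1nccc(-c2[nH]c(-c3ccccc3)nc2-c2ccc(Cl)c(O)c2)n1)c1cccc2ccccc12`, reached from compound 3 by one change: naphthalen-1-yl in place of 4-(trifluoromethyl)phenyl on a sulfonyl sulfur.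

Among the measured compounds shown here, only one measured step involves a change on this sulfonyl group, a 1.5-fold lower number from compound 2 to compound 3 (0.19 log units; within the scatter). That step swaps trifluoromethyl for bromo, so it shows one exchange of groups on the ring without a visible effect, but it says nothing directly about naphthalen-1-yl. For the measured compounds named here, compound 1 is the only measured compound carrying naphthalen-1-yl on the sulfonyl sulfur, and its 3710 nM is the lowest number here. However, compound 1 has fluoro on the core where compound 3 has chloro, and no measured step separates these two changes. Only part of that gap is therefore expected to carry over.

The expected change in this assay is towards a lower number but within the scatter, an estimated 1.8-fold lower number from compound 3 to compound 4 (0.26 log units; within the scatter). For compound 4 the estimated value is 5500 nM, with an expected range of 2300 nM to 12000 nM.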

Compound 4, half-maximal inhibitory concentration: 7720 nM
Compound 4: middle estimate off by 1.4-fold (0.15 log units), on the low side, within the range that was stated.
By their numbers in this assay, from the lowest: compound 1; then compounds 4, 3 and 2 (each within the scatter of the next).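

Working notes on the sulfonyl position, read in this assay: with the chloro core held constant, the change to naphthalen-1-yl gives a 1.3-fold lower number from compound 3 to compound 4 (0.12 log units; within the scatter) and a 2.0-fold lower number from compound 2 to compound 4 (0.30 log units; within the scatter), so 4-bromophenyl, 4-(trifluoromethyl)phenyl and naphthalen-1-yl on the sulfonyl sulfur all lie within the scatter of one another, with no exchange among these three aryl groups standing out. Among the compounds shown here, the halogen on the core can now be read on its own for the first time, with naphthalen-1-yl held constant: chloro in place of fluoro on an aromatic carbon gives a 2.1-fold higher number from compound 1 to compound 4 (0.32 log units; beyond the scatter), a modest step beyond the scatter, and the only single change that clears it. No measured evidence accounts for either observation.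

From the compounds shown here alone, the halogen comparison rests on this one pair, so it remains open whether fluoro in place of chloro gives a similar step with 4-bromophenyl or 4-(trifluoromethyl)phenyl on the sulfonyl sulfur. The compounds shown also leave open whether a non-aromatic group on the sulfonyl sulfur, such as a simple alkyl chain or a chain ending in an amine or a carboxylic acid, would move the number beyond the scatter.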